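This account rests on a few compounds, and the source may have more. Where it says the series, first, only, none or still open, it means among the compounds named here.

Compound 1 `Cc1ccc(NC(=O)Nc2cc(/C(=N/O)Nc3ccc(C)cc3)ccc2N(CC(C)C)CC(C)C)cc1` gives 1560 nM in an assay on isolated protein for inhibition of Indoleamine 2,3-dioxygenase 1 (Homo sapiens); a lower number here means a stronger inhibitor, a higher number a weaker inhibitor.
Compound 2 `CC(C)CN(CC(C)C)c1ccc(/C(=N/O)Nc2ccc(F)c(Br)c2)cc1NC(=O)Nc1cncnc1` gives > 3000 nM, which is a limit of the assay and not a number.

Compound 2 thus stands at the limit of > 3000 nM in this assay, at which 1 of the 2 values shown sits, with no figure of its own. Compound 3 `Cc1ccc(N/C(=N\O)c2ccc(N(CC(C)C)CC(C)C)c(NC(=O)Nc3cncnc3)c2)cc1` differs from compound 2 by 4-methylphenyl in place of 3-bromo-4-fluorophenyl on an amine nitrogen. Going by the values given here, no measured pair shows this change, but compound 1, which carries the same 4-methylphenyl group, gives 1560 nM in this assay. The expected step is an at least 1.2-fold lower number from compound 2 to compound 3 (0.07 log units; that floor lies within the scatter), toward stronger inhibition, though perhaps within the scatter. Compound 3 is estimated at 2500 nM, between 800 nM and 8000 nM.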

Compound 3, half-maximal inhibitory concentration: 2320 nM
The estimate for compound 3 lay 1.1-fold (0.03 log units) above the measured number, within the range that was stated.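

Going by these compounds, the change to 4-methylphenyl on the amine nitrogen gives an at least 1.2-fold lower number from compound 2 to compound 3 (0.11 log units; that floor lies within the scatter) in this assay and starts from a limit of the assay, so its full size stays unknown. Pyrimidin-5-yl in place of 4-methylphenyl on the amide-type nitrogen gives a 1.5-fold higher number from compound 1 to compound 3 (0.17 log units; within the scatter) and so shows no change beyond the scatter in this assay for this pair, a comparison the earlier compounds could not offer. Still open, on these data alone, is whether a carboxylic acid or an amine on the amide-type nitrogen would move the number beyond the scatter.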